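The source may report more compounds than this note shows. Statements on the series, on what has been measured and on what is new or still open speak of the compounds shown alone.

Series notes. The compounds share the core of compound 1 `CCOC(=O)C1(C(=O)NCc2ccc(C)cc2)CC1c1cc(OC)c(OC)c(OC)c1`; compound 2 `CCOC(=O)[C@@]1(C(=O)NCc2ccc(C)cc2)C[C@@H]1c1cc(OC)c(OC)c(OC)c1` carries the same groups with a drawn configuration, compound 3 `CCOC(=O)[C@@]1(C(=O)Nc2ccccc2Cl)C[C@@H]1c1cc(OC)c(OC)c(OC)c1` carries 2-chlorophenyl on the amide-type nitrogen, and compound 4 `CCOC(=O)[C@@]1(C(=O)NCc2ccc(C)cc2)C[C@H]1c1cc(OC)c(OC)c(OC)c1` is the remaining configurational partner of compound 2.

In a functional assay on SW480 cells (Homo sapiens) for cytotoxicity, read by MTT assay, with a stated time of 48 h (a higher number here means a weaker inhibitor, a lower number a stronger inhibitor), compound 1 gives 29000 nM; > 100000 nM (2 entries). For compound 2 the assay reports only a limit, > 100000 nM. Compound 3 gives 46700 nM. Within the data shown here, the one measured step, an at least 2.1-fold lower number from compound 2 to compound 3 (0.33 log units; beyond the scatter), is the sole comparison beyond the scatter, and it concerns the amide substituent rather than the configuration, so it does not bear directly on the step to compound 4. Among the measured compounds shown here, that step is the two compounds have the same atoms and bonds and differ only in configuration as drawn: 1 of 2 stereo elements differ; a stereocentre at a saturated ring carbon is drawn R in compound 2 and S in compound 4, with no measured counterpart. The spread among the entries of compound 1 the several entries of compound 1 in this assay, 29000 nM; > 100000 nM (2 entries) and the fact that compound 2 is drawn with a defined configuration while compound 1 is not the fact that one of compounds 1 and 2 is drawn with a defined configuration and the other without, at the place where they differ leave room for compound 4 to sit away from compound 2. A modest step down is expected, an at least 2.0-fold lower number from compound 2 to compound 4 (0.30 log units; that floor lies within the scatter), with a fair chance that the assay again reports only a limit. Compound 4 is estimated at 50000 nM, between 15000 nM and 150000 nM.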

Compound 4, half-maximal inhibitory concentration: > 100000 nM
Compound 4 was reported as a limit; the forecaster's own chance of this, stated with the estimate: 45%; middle value at least 2.0-fold (0.30 log units) away from the limit.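

In this assay compound 4 gives > 100000 nM, a limit. Among these compounds, compound 2 gives > 100000 nM, also a limit, so no step between compound 2 and compound 4 can be read. The compounds shown leave open whether the configuration at the saturated ring carbon changes the read-out.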